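Fluoro to methyl: one step carried over to compound 4

A few compounds are considered here, and "the series" means these few. Any claim that something is new, unique, unknown or untested is made for them only; others in the source may bear on it.

Of the compounds shown here, three have been measured in a functional assay on A549 cells (Homo sapiens) for inhibition, read by sulforhodamine B assay, with a stated time of 48 h; a lower number here means a stronger inhibitor, a higher number a weaker inhibitor. Compound 1 `COc1ccc(C(O)(Cc2ccc(C)cc2)c2cccc3ccccc23)c(OC)c1OC` gives 18700 nM, compound 2 `COc1ccc(C(O)(Cc2ccc(F)cc2)c2cccc3ccccc23)c(OC)c1OC` gives 5940 nM, and compound 3 `COc1ccc(/C(=C/c2ccc(F)cc2)c2cccc3ccccc23)c(OC)c1OC` gives 18600 nM. Between compound 2 and compound 1 the change is methyl in place of fluoro on an aromatic carbon and the step is a 3.1-fold higher number from compound 2 to compound 1 (0.50 log units; beyond the scatter). The difference between the core of compound 2 and the core of compound 3 is not broken down here; their values lie apart beyond the scatter, while compound 3 and compound 1 sit within the scatter of each other. Compound 4 `COc1ccc(/C(=C/c2ccc(C)cc2)c2cccc3ccccc23)c(OC)c1OC` is not yet measured; it differs from compound 3 by methyl in place of fluoro on an aromatic carbon, the same change as from compound 2 to compound 1, at the same place. Compound 4 is expected to give a higher number in this assay, with an estimated step of a 2.4-fold higher number from compound 3 to compound 4 (0.38 log units; beyond the scatter), because the earlier step of a 3.1-fold higher number from compound 2 to compound 1 (0.50 log units; beyond the scatter) rests on a single pair and on a different core, so the range is kept wide. Compound 4 is estimated at 45000 nM, between 15000 nM and 120000 nM.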

Compound 4, half-maximal inhibitory concentration: 19600 nM
Compound 4: middle estimate off by 2.3-fold (0.36 log units), on the high side, and the stated range covers the measured number.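

In this assay, 4-fluorophenyl to 4-methylphenyl on the second core gives a 1.1-fold higher number from compound 3 to compound 4 (0.02 log units; within the scatter), so the size of the earlier step does not carry over to this core. The two steps differ: the same change on two cores in this assay, a 3.1-fold higher number (0.50 log units; beyond the scatter) from compound 2 to compound 1 and a 1.1-fold higher number (0.02 log units; within the scatter) from compound 3 to compound 4, 3.0-fold (0.48 log units) apart, beyond the scatter of two such steps

In these four compounds, the effect of this change therefore depends on the core, but with a single pair on each core, this does not show which difference between the cores is responsible or how either step would hold up in a wider set.

On these data alone, it remains open whether chloro, methoxy or an amine at the same place would follow the step seen on either core. As far as these compounds go, a carboxylic acid there is equally open.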